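The source may report more compounds than this note shows. Statements on the series, on what has been measured and on what is new or still open speak of the compounds shown alone.

Measured so far in a physicochemical assay for lipophilicity, measured as octanol-water partition, at pH 7.4; a higher number here means a more lipophilic compound, a lower number a more polar compound:
compound 1 `Cc1ccc2[nH]c(C(=O)N[C@H]3CN(S(=O)(=O)c4cnccn4)C[C@@H]3C(=O)NCCN(C)C)cc2c1`: 1
compound 2 `O=C(N[C@H]1CN(S(=O)(=O)c2ccccc2)C[C@@H]1C(=O)N[C@H]1CCCNC1)c1cc(C2CC2)n[nH]1`: 0.2
compound 3 `O=C(N[C@H]1CN(S(=O)(=O)c2ccccc2)C[C@@H]1C(=O)N[C@H]1CCCNC1)c1cn(C2CC2)cn1`: -0.7

Compound 3 is the lowest of the three, at -0.7. Compound 2 lies nearest to it and compound 1 furthest.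

Next is compound 4 `O=C(N[C@H]1CN(S(=O)(=O)c2ccccc2)C[C@@H]1C(=O)N[C@H]1CCCNC1)c1nnc(-c2ccc(F)cc2)s1`. Relative to compound 3 the change is a group of 12 heavy atoms (8 carbon, 2 nitrogen, 1 fluorine, 1 sulfur; one five-membered aromatic ring with 3 hetero atoms, one six-membered aromatic ring of carbon only) in place of a group of 8 heavy atoms (6 carbon, 2 nitrogen; one three-membered non-aromatic ring of carbon only, one five-membered aromatic ring with 2 hetero atoms), on a carbonyl carbon.

Among the measured compounds shown here, one measured step bears on this, at the same carbonyl carbon: a number 0.90 log units lower from compound 2 to compound 3 (beyond the scatter). That step is modest and brought in the 1-cyclopropyl-1H-imidazol-4-yl group that now leaves. For the measured compounds named here, no measured step involves the entering group, so the size remains uncertain. An upward move larger than that step is expected, estimated as a number 1.70 log units higher from compound 3 to compound 4 (beyond the scatter). The expected value for compound 4 is 1, with an estimated range of 0.2 to 1.8.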

Compound 4, distribution coefficient: 1
Estimate against measurement, compound 4: no gap at the digits printed, and the stated range covers the measured number.
By their numbers in this assay, from the lowest: compound 3; then compound 2; then compounds 1 and 4 (each within the scatter of the next).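

In this assay, the group of 12 heavy atoms on the carbonyl carbon gives a number 1.70 log units higher from compound 3 to compound 4 (beyond the scatter) and a number 0.80 log units higher from compound 2 to compound 4 (beyond the scatter), placing it above both groups of 8 heavy atoms at this position. With the rest of the core unchanged, this single position therefore moves the number both down and up across compounds 2, 3 and 4. Nothing measured here accounts for either shift.

Still open, as far as these compounds go, is whether the six-membered aromatic ring of carbon only or the five-membered aromatic ring with 3 hetero atoms carries the rise. From the compounds shown here alone, it is also open how an amine or a carboxylic acid on that carbonyl carbon would compare.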